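From hydroxy to fluoro: one step still open

The source may hold more compounds than are shown below. What is called first, only, known or untested is meant among the compounds shown, and "the series" means these compounds.

In a functional assay on SNB-19 cells (Homo sapiens) for inhibition (on this read-out higher numbers stand for weaker inhibition of growth and lower numbers for stronger inhibition of growth), compound 1 (`COc1ccc(-n2cnnc2-c2cc(OC)c(OC)c(OC)c2)cc1`) gives 5250 nM as its reading. On the same read-out compound 2 (`COc1cc(-c2nncn2-c2ccc(N(C)C)cc2)cc(OC)c1OC`) gives 204 nM and compound 3 (`COc1ccc(-n2cnnc2-c2cc(OC)c(OC)c(OC)c2)cc1O`) gives 407 nM as theirs. Compound 3 thus stands level with compound 2 within the scatter, and both lie well under compound 1.

The next compound is compound 4 (`COc1ccc(-n2cnnc2-c2cc(OC)c(OC)c(OC)c2)cc1F`), which has fluoro in place of hydroxy on an aromatic carbon , ortho to a methoxy group and meta to a large group. The measured step that bears most directly on this is the large one of a 13-fold lower number from compound 1 to compound 3 (1.11 log units; beyond the scatter) when hydroxy took the place of hydrogen on that same carbon. The other large step of a 26-fold lower number from compound 1 to compound 2 (1.41 log units; beyond the scatter) with dimethylamino in place of methoxy concerns a different group and bears on it only loosely. Within the data shown here, no measured compound carries fluoro, so the size of the change is uncertain. Compound 4 lacks the hydroxy that came with a 13-fold lower number from compound 1 to compound 3 (1.11 log units; beyond the scatter) and is therefore expected to give back part of that gain, though not all of it. The expected change is a 3.7-fold higher number from compound 3 to compound 4 (0.57 log units; beyond the scatter) as a moderate rise in the number. The estimate for compound 4 is 1500 nM within an expected range from 350 nM to 6000 nM in this assay once measured.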

Compound 4, concentration for 50% growth inhibition: 6310 nM
The estimate for compound 4 lay 4.2-fold (0.62 log units) below the measured number, and the stated range ends below it.
By their numbers in this assay, from the lowest: compounds 2 and 3 (each within the scatter of the next); then compounds 1 and 4 (each within the scatter of the next).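

In this assay, the step of a 16-fold higher number from compound 3 to compound 4 (1.19 log units; beyond the scatter) shows that at this aromatic carbon, ortho to a methoxy group and meta to a large group, fluoro does not stand in for hydroxy, and the gain that came with hydroxy is lost. The step of a 1.2-fold higher number from compound 1 to compound 4 (0.08 log units; within the scatter), which lies within the scatter, shows that fluoro in place of hydrogen on the same carbon leaves the reading level, so of the two groups shown here only hydroxy goes with a lower number than hydrogen. Hydroxy counts as a hydrogen-bond donor and acceptor and fluoro as neither, but no measurement at hand says what lies behind the difference in growth inhibition.

What the compounds shown leave open is whether hydroxy is alone in this, since an amino group or a carboxylic acid on that same carbon could give a reading on either side of these. They also leave open whether hydroxy and dimethylamino, each of which goes with a large step on its own, would add to one another in a single compound.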